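The compounds below may be only part of what the source reports. "The series", "measured", "known", "first", "only" and "open" are said of these compounds alone.

The measured compounds are:

compound 1, `COc1cc([C@](O)(CCN(C)C)[C@@H](c2cc3cc(Br)ccc3nc2OC)c2ccnc(OC)c2OC)cc(OC(F)F)n1`, with 9800 ng.h/mL;
compound 2, `COc1cc([C@](O)(CCN(C)C)[C@@H](c2cc3cc(C#N)ccc3nc2OC)c2ccnc(OC)c2OC)cc(OC(F)F)n1`, with 3000 ng.h/mL;
compound 3, `COc1cccc([C@H](c2cc3cc(Br)ccc3nc2OC)[C@@](O)(CCN(C)C)c2cc(SC)nc(SC)c2)c1F`, with 8400 ng.h/mL.

All three were studied in an ADME assay on the whole organism (Mus musculus, strain CD-1) for pharmacokinetics, at a dose of 10 mg/kg by the oral route; a lower number here means less compound in the circulation, a higher number more compound in the circulation at the dose given. Compound 1 and compound 2 share a core and differ in one place: cyano in place of bromo on an aromatic carbon. That change gave a 3.3-fold lower number from compound 1 to compound 2 (0.51 log units; beyond the scatter). Compound 3 is built on a different core; the difference between the two cores is not broken down here. In this assay compound 3 and compound 1 give numbers that lie within the usual scatter of each other, while compound 2 stands apart from both.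

Compound 4, `COc1cccc([C@H](c2cc3cc(C#N)ccc3nc2OC)[C@@](O)(CCN(C)C)c2cc(SC)nc(SC)c2)c1F`, has not yet been measured. It is related to compound 3 by cyano in place of bromo on an aromatic carbon, the same change that separates compound 1 from compound 2. Since that earlier step was a 3.3-fold lower number from compound 1 to compound 2 (0.51 log units; beyond the scatter), compound 4 is expected to show a step of similar size relative to compound 3, namely a 3.4-fold lower number from compound 3 to compound 4 (0.53 log units; beyond the scatter). On this basis compound 4 is estimated to give 2500 ng.h/mL in this assay, with a likely range from 1000 ng.h/mL to 6000 ng.h/mL.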

Compound 4, area under the concentration-time curve: 1100 ng.h/mL
The estimate for compound 4 lay 2.3-fold (0.36 log units) above the measured number; low and high end bracket the measured number.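

In this assay, cyano in place of bromo on an aromatic carbon gave a 7.6-fold lower number from compound 3 to compound 4 (0.88 log units; beyond the scatter), so the fall seen on the core of compound 1 recurred on the core of compound 3. Although the second step looks larger, the two steps cannot be told apart: the same change on two cores in this assay, a 3.3-fold lower number (0.51 log units; beyond the scatter) from compound 1 to compound 2 and a 7.6-fold lower number (0.88 log units; beyond the scatter) from compound 3 to compound 4, 2.3-fold (0.37 log units) apart, within the scatter of two such steps This shows that the change lowered the number on both cores, by amounts that do not differ beyond the scatter, but two pairs do not show that it would carry over in the same way to any further core, and they do not explain the fall.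

The compounds shown leave open whether chloro, methyl or trifluoromethyl on that same aromatic carbon would keep the number closer to that of the bromo compounds or lower it as cyano does. They also leave open whether the lower numbers arise from less compound being taken up or from compound being cleared faster.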